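Methoxy for ethyl on the aryl ring of compound 3

A few compounds are considered here, and "the series" means these few. Any claim that something is new, unique, unknown or untested is made for them only; others in the source may bear on it.

Going by the values given here, compound 3 `CCc1ccc(C(CCN2CCN(c3ccccc3OC)CC2)Oc2ccc(C(=O)Nc3ccccc3OCCCC(=O)O)cc2)cc1` gives 39.8 nM in an assay on Prostate gland (Oryctolagus cuniculus) for inhibition of Adrenergic receptor alpha-1 (Homo sapiens) (a higher number here means weaker binding, a lower number tighter binding), the highest of the three numbers so far. Compound 1 `COc1ccccc1N1CCN(CCC(Oc2ccc(C(=O)Nc3ccccc3OCCCC(=O)O)cc2)c2ccccc2)CC1` gives 25.1 nM in this assay, and a 1.6-fold higher number from compound 1 to compound 3 (0.20 log units; within the scatter), so the two sit within the scatter of each other. Compound 2 `COc1ccccc1N1CCN(CCC(Oc2ccc(C(=O)Nc3ccccc3OCCCC(=O)O)cc2)c2ccc(C)cc2)CC1` gives 15.9 nM in this assay. The step of a 2.5-fold higher number from compound 2 to compound 3 (0.40 log units; beyond the scatter) is the only one here beyond the scatter.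

Compound 4 `COc1ccc(C(CCN2CCN(c3ccccc3OC)CC2)Oc2ccc(C(=O)Nc3ccccc3OCCCC(=O)O)cc2)cc1` differs from compound 3 by one change: methoxy in place of ethyl on an aromatic carbon, on an aromatic carbon of a six-membered aromatic ring of carbon only, para to a large group. Among the compounds with values here, no measured step puts a methoxy at this place. The steps that touch the same ring are a 1.6-fold lower number from compound 1 to compound 2 (0.20 log units; within the scatter) and a 1.6-fold higher number from compound 1 to compound 3 (0.20 log units; within the scatter), both within the scatter, so small groups here have moved the number little. For compound 4 the expected step in this assay is a 1.4-fold lower number from compound 3 to compound 4 (0.15 log units; within the scatter), with no confident direction. Compound 4 is estimated at 28 nM, with a range from 12 nM to 65 nM.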

Compound 4, dissociation constant: 200 nM
For compound 4 the middle estimate is 7.1-fold (0.85 log units) below the measured one; the whole stated range lies below it.
By their numbers in this assay, from the lowest: compounds 2, 1 and 3 (each within the scatter of the next, the first and the last beyond it); then compound 4.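

In this assay, going by these compounds alone, methoxy is the first group at this place, on an aromatic carbon para to a large group, to stand beyond the scatter of all the others: (a 5.0-fold higher number from compound 3 to compound 4 (0.70 log units; beyond the scatter)), (a 13-fold higher number from compound 2 to compound 4 (1.10 log units; beyond the scatter)) and (an 8.0-fold higher number from compound 1 to compound 4 (0.90 log units; beyond the scatter)). Methyl and ethyl each stayed within the scatter of hydrogen, so the earlier tolerance at this place does not extend to methoxy, even though methoxy and ethyl have the same count of 2 heavy atoms and differ by one oxygen for one carbon and by one hydrogen-bond acceptor. Nothing available explains this rise in the number.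

A single oxygen-linked group cannot show whether the rise goes with the oxygen itself or with this particular group. A hydroxyl, an amine or a longer chain such as ethoxy at this place would separate those readings.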